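From pyrrolidin-1-yl to 4-acetylphenoxy: working notes

A few compounds are considered here, and "the series" means these few. Any claim that something is new, unique, unknown or untested is made for them only; others in the source may bear on it.

In a functional assay on HeLa cells (Homo sapiens) for cytotoxicity, read by sulforhodamine B assay, with a stated time of 72 h (a higher number here means a weaker inhibitor, a lower number a stronger inhibitor), compound 1 (`C=C1C(=O)O[C@@H]2CC(C)=C([C@@H](C)CCCOC(C)=O)[C@@H](OC(=O)CCl)[C@H]12`) gives 28500 nM, compound 2 (`C=C1C(=O)O[C@@H]2CC(C)=C([C@@H](C)CCCOC(C)=O)[C@@H](OC(=O)CN3CCCC3)[C@H]12`) gives 12700 nM and compound 3 (`C=C1C(=O)O[C@@H]2CC(C)=C([C@@H](C)CCCOC(C)=O)[C@@H](OC(=O)COc3cccc(C(C)=O)c3)[C@H]12`) gives 38600 nM. Compound 2 holds the lowest of these three numbers, and a 2.2-fold lower number from compound 1 to compound 2 (0.35 log units; beyond the scatter) separates it from the chloro compound.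

Compound 4 (`C=C1C(=O)O[C@@H]2CC(C)=C([C@@H](C)CCCOC(C)=O)[C@@H](OC(=O)COc3ccc(C(C)=O)cc3)[C@H]12`) keeps the shared core and differs from compound 2 in one group: 4-acetylphenoxy in place of pyrrolidin-1-yl on a saturated chain carbon bound to a carbonyl carbon. In words, this is 4-acetylphenoxy in place of pyrrolidin-1-yl on a saturated chain carbon bound to a carbonyl carbon.

Going by the values given here, the nearest precedent is compound 3, which carries 3-acetylphenoxy in that place, with a 3.0-fold higher number from compound 2 to compound 3 (0.48 log units; beyond the scatter). Against chloro, the same group shows a 1.4-fold higher number from compound 1 to compound 3 (0.13 log units; within the scatter). Among the compounds with values here, no measurement yet covers the 4-acetylphenoxy group itself, so a modest rise of similar size is expected in this assay, towards weaker inhibition. The expected change is a 2.8-fold higher number from compound 2 to compound 4 (0.44 log units; beyond the scatter). For compound 4 the estimate is 35000 nM, with an expected range of 17000 nM to 70000 nM.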

Compound 4, half-maximal inhibitory concentration: 43900 nM
The estimate for compound 4 lay 1.3-fold (0.10 log units) below the measured number; the measured number falls inside the stated range.
By their numbers in this assay, from the lowest: compound 2; then compounds 1, 3 and 4 (each within the scatter of the next).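

Exchanging 3-acetylphenyl for 4-acetylphenyl on an oxygen on a saturated carbon gives a 1.1-fold higher number from compound 3 to compound 4 (0.06 log units; within the scatter) in this assay and so does not separate the two acetylphenoxy groups at this place. The change from pyrrolidin-1-yl to 4-acetylphenoxy gives a 3.5-fold higher number from compound 2 to compound 4 (0.54 log units; beyond the scatter) and repeats, with a second acetylphenoxy group, the modest rise already seen with compound 3, while 4-acetylphenoxy in place of chloro gives a 1.5-fold higher number from compound 1 to compound 4 (0.19 log units; within the scatter) and stays level with the chloro compound. No supporting data bear on why pyrrolidin-1-yl stands apart from these groups.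

On these data alone, whether the lower number of compound 2 belongs to pyrrolidin-1-yl alone or extends to another amine, such as piperidin-1-yl or diethylamino, stays open. Also open, as far as these compounds go, is whether unsubstituted phenoxy reads differently from the two acetylphenoxy groups.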